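Compound 3 to compound 4: swapping the aryl group

A few compounds are considered here, and "the series" means these few. Any claim that something is new, unique, unknown or untested is made for them only; others in the source may bear on it.

Measured in a functional assay on MGC-803 cells (Homo sapiens) for inhibition, read by MTT assay, with a stated time of 72 h; on this read-out lower numbers stand for stronger inhibition and higher numbers for weaker inhibition:
- Compound 1 `C#CCSc1nc(Nc2ccc(C)cc2)c2ccncc2n1`: 8090 nM
- Compound 2 `C#CCSc1nc(Nc2ccc(F)cc2)c2ccncc2n1`: 15800 nM
- Compound 3 `C#CCSc1nc(Nc2ccc(Br)cc2)c2ccncc2n1`: 26000 nM
- Compound 4 `C#CCSc1nc(Nc2cccc(O)c2)c2ccncc2n1`: not yet measured

Compound 3 stands clearly apart only from compound 1, with a 3.2-fold higher number from compound 1 to compound 3 (0.51 log units; beyond the scatter). Against compound 2 the picture is a 1.6-fold higher number from compound 2 to compound 3 (0.22 log units; within the scatter). Compound 4 brings one change: 3-hydroxyphenyl in place of 4-bromophenyl on a nitrogen on an aromatic ring. The remaining measured step is a 2.0-fold higher number from compound 1 to compound 2 (0.29 log units; within the scatter). These steps each swap one group on an aromatic carbon, and none involves 3-hydroxyphenyl, so they offer only a rough size and no firm direction. A modest step is expected, leaning towards the lower numbers of the set, and the expected change is a 1.9-fold lower number from compound 3 to compound 4 (0.27 log units; within the scatter). For compound 4 the estimated value is 14000 nM, with an expected range of 4000 nM to 40000 nM.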

Compound 4, half-maximal inhibitory concentration: 15700 nM
The estimate for compound 4 lay 1.1-fold (0.05 log units) below the measured number; low and high end bracket the measured number.
By their numbers in this assay, from the lowest: compounds 1, 4, 2 and 3 (each within the scatter of the next, the first and the last beyond it).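

Replacing 4-bromophenyl, 4-fluorophenyl or 4-methylphenyl with 3-hydroxyphenyl, which adds a hydrogen-bond donor and acceptor to the group on this nitrogen, leaves every step within the scatter (a 1.7-fold lower number from compound 3 to compound 4 (0.22 log units; within the scatter)), (a 1.0-fold lower number from compound 2 to compound 4 (0.00 log units; within the scatter)) and (a 1.9-fold higher number from compound 1 to compound 4 (0.29 log units; within the scatter)). This position therefore accepts 3-hydroxyphenyl without a clear change in the number. Nothing available here explains this result.

Still open, going by these compounds, is whether an amine or a carboxylic acid on the phenyl ring would shift the number beyond the scatter. The same question applies to a longer chain in place of the ring.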